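The compounds below may be only part of what the source reports. "The series", "measured", "known", "first", "only" and "open" are said of these compounds alone.

Working notes on the series. In a physicochemical assay for lipophilicity, read by HPLC, at pH 7.4 (on this read-out lower numbers stand for lower lipophilicity and higher numbers for higher lipophilicity), compound 1 `C[C@@H](Oc1cc2cnn(CCC(=O)O)c2cc1Cl)c1ccccn1` gives 1.7, compound 2 `Cc1ccc([C@@H](C)Oc2cc3oc(=O)n(CCC(=O)O)c3cc2Cl)nc1` gives 2.02 and compound 3 `O=C(O)CCn1c(=O)oc2cc(OCC3CCC3)c(Cl)cc21` gives 2.9. Compound 3 stands highest of the three, and its distance from each of the other two lies beyond the scatter.

Compound 4 `O=C(O)CCn1c(=O)oc2cc(OCc3ccccc3)c(Cl)cc21` has no reading yet. It differs from compound 3 by phenyl in place of cyclobutyl on a saturated chain carbon bound to an oxygen on an aromatic ring, which amounts to phenyl in place of cyclobutyl on a saturated chain carbon bound to an oxygen on an aromatic ring. The same difference can be read as cyclobutylmethoxy to benzyloxy.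

Within the data shown here, no two compounds measured so far differ in one place only, so the series offers no direct precedent for this change, and the expectation rests on the structural change and on compound 3 at 2.9. In this assay a small downward step is expected, probably none beyond the scatter. The estimated step is a number 0.10 log units lower from compound 3 to compound 4 (within the scatter). Compound 4 is expected at 2.8, with an estimated range of 2.4 to 3.2.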

Compound 4, distribution coefficient: 2.71
Estimate against measurement, compound 4: 0.09 log units above; the range from low to high includes it.
By their numbers in this assay, from the lowest: compound 1; then compound 2; then compounds 4 and 3 (each within the scatter of the next).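

The series now holds its first comparison in one place: in this assay, phenyl in place of cyclobutyl on a saturated chain carbon bound to an oxygen on an aromatic ring gives a number 0.19 log units lower from compound 3 to compound 4 (within the scatter). At this place, then, a four-membered non-aromatic ring of carbon only and a six-membered aromatic ring of carbon only read alike on this scale, even though the heavy atoms go from 4 to 6. No measurement on these groups bears on why the two read alike.

On these data alone, it remains open whether an amine, a carboxylic acid or a longer chain at this same place would stay as close to compound 3. The compounds shown also leave open whether this change gives a similar step on the core of compound 1.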